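Side-chain ester variation in the chlorinated core series

This account rests on a few compounds, and the source may have more. Where it says the series, first, only, none or still open, it means among the compounds named here.

Measured so far:
Compound 1, `Clc1nc(NC2CC2)c2ncn(C3CCCCO3)c2n1`: in a functional assay on the whole organism with Mus musculus as the target, with a stated time of 90 min, at a dose of 25 umol/kg by the oral route (a lower number here means a weaker effect, a higher number a stronger effect of the compound at the dose given), compound 1 gives 11.9%.
Compound 2, `O=C(CN(c1nc(Cl)nc2c1ncn2C1CCCCO1)C1CC1)N[C@@H](CC(=O)OCc1ccccc1)C(=O)OCc1ccccc1`: in this assay compound 2 gives 25.1%.

Compound 2 stands highest of the two numbers in this assay; the nearest, compound 1, lies lower by a gap beyond the usual scatter. For the measured compounds named here, no pair of measured compounds differs in a single place, so no step size is known from measurement.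

Compound 3, `CC(C)C[C@H](NC(=O)CN(c1nc(Cl)nc2c1ncn2C1CCCCO1)C1CC1)C(=O)OCc1ccccc1`, is the next entry. It differs from compound 2 in one place: isopropyl in place of benzyloxycarbonyl on a saturated chain carbon, two bonds along the chain from an amide-type nitrogen and a carbonyl carbon. The amide chain to the shared core and the remaining benzyl ester are kept; only the substituent on the saturated chain carbon is exchanged.

Going by the values given here, with no measured step to lean on, the expectation for this assay rests on compound 2 alone, which gives 25.1%. The step of a number 3.1 percentage points lower from compound 2 to compound 3 (within the scatter) is expected to be small, in either direction, and most likely none beyond the scatter. Compound 3 is estimated at 22%, with a range from 6% to 40%.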

Compound 3, a percentage reported as activity, at one dose (the size of the read-out at that dose, not a potency): 28.2%
Beside the measured number, compound 3's estimate is 6.2 percentage points below it; measured number inside the range.
By their numbers in this assay, from the lowest: compound 1; then compounds 2 and 3 (each within the scatter of the next).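

In this assay, for the compounds shown here, the step of a number 3.1 percentage points higher from compound 2 to compound 3 (within the scatter) is the only measured change on the saturated chain carbon, two bonds along the chain from an amide-type nitrogen and a carbonyl carbon. Isopropyl in place of benzyloxycarbonyl takes the substituent from 10 heavy atoms to 3 and removes one six-membered aromatic ring of carbon only and 2 hydrogen-bond acceptors, yet the step stays within the scatter. For this pair, with the amide chain and the remaining benzyl ester kept, the read-out therefore does not depend on that aromatic ring or on the second ester, and no available measurement bears on the reason for this.

A single step leaves open how this assay responds to other groups at this place, such as a free carboxylic acid, an amine or a longer chain. From the compounds shown here alone, it is also open whether the remaining benzyl ester can be exchanged for a methyl ester or a free carboxylic acid without a step beyond the scatter.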